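The source may hold more compounds than are shown below. What is called first, only, known or untested is meant among the compounds shown, and "the series" means these compounds.

Compound 1 `C=C(C)C(=O)N(Cc1ccc(OC)c(O)c1)c1cc(OC)c(OC)c(OC)c1` carries an (1-methylethenyl)carbonyl group on its amide nitrogen. In a functional assay on MGC-803 cells (Homo sapiens) for inhibition, read by MTT assay, with a stated time of 48 h (a lower number here means a stronger inhibitor, a higher number a weaker inhibitor), compound 1 gives 390 nM, the lowest of the two numbers reported. Compound 3 `COc1ccc(CNc2cc(OC)c(OC)c(OC)c2)cc1C`, which lacks the acyl group altogether, gives 56800 nM. Compound 2 `COc1cc(NCc2ccc(Br)cc2)cc(OC)c1OC` reaches only a limit of this assay, > 80000 nM (the limit of > 80000 nM in this assay, at which 1 of the 3 values shown sits). Compound 4 `COc1ccc(CN(C(=O)CBr)c2cc(OC)c(OC)c(OC)c2)cc1O` keeps the whole of compound 1 except at the carbonyl carbon, where the change reads (bromomethyl in place of 1-methylethenyl on a carbonyl carbon). Within the data shown here, no measured pair shows this particular change, so the size of the step can only be guessed; a modest shift is expected, near the scatter of repeated measurements. Compound 4 is therefore estimated at 300 nM, between 80 nM and 1500 nM, a step of a 1.3-fold lower number from compound 1 to compound 4 (0.11 log units; within the scatter).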

Compound 4, half-maximal inhibitory concentration: 140 nM
Compound 4: middle estimate off by 2.1-fold (0.33 log units), on the high side, within the range that was stated.
By their numbers in this assay, from the lowest: compound 4; then compound 1; then compound 3. At a limit, above all of these: compound 2.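

Among these compounds, the earlier compounds offered no pair differing in one place, so this is the first direct reading at this carbonyl carbon: a 2.8-fold lower number from compound 1 to compound 4 (0.44 log units; beyond the scatter). The group that enters has no double bond outside aromatic rings, so in this assay that double bond in 1-methylethenyl is not required for a number this low. No measured reason for the step is given among the compounds shown.

Open, on these data alone, is how a methyl, a chloromethyl or a longer chain on this carbonyl carbon would read. Also open, as far as these compounds go, is what removing the acyl group alone would do to compound 1.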